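The source may hold more compounds than are shown below. What is called first, only, known or untested is meant among the compounds shown, and "the series" means these compounds.

The three measured compounds and their values:

compound 1, `COc1cc(-c2cc(/C=C/C(=O)c3ccc(N)cc3)[nH]n2)cc(OC)c1OC`: in a functional assay on SW-620 cells (Homo sapiens) for cytotoxicity, read by sulforhodamine B assay, with a stated time of 48 h, tested at 100 uM (on this read-out higher numbers stand for a weaker effect at the one concentration tested and lower numbers for a stronger effect), compound 1 gives -40%
compound 2, `COc1cc(-c2cc(/C=C/C(=O)c3ccc(Cl)c(Cl)c3)[nH]n2)cc(OC)c1OC`: in this assay compound 2 gives -5%
compound 3, `COc1ccc(C(=O)/C=C/c2cc(-c3cc(OC)c(OC)c(OC)c3)n[nH]2)cc1`: in this assay compound 3 gives -39%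

All three share the same core and differ only in the ring that hangs on the carbonyl carbon. Compound 3 stands close to compound 1: the step is a number 1 percentage points higher from compound 1 to compound 3 (within the scatter), within the scatter, so the two cannot be told apart. Compound 3 stands far from compound 2: the step is a number 34 percentage points lower from compound 2 to compound 3 (beyond the scatter), beyond the scatter, and the other step to compound 2, a number 35 percentage points higher from compound 1 to compound 2 (beyond the scatter), is of the same size. In both steps the ring carrying two chlorines gave the higher, weaker number.

Compound 4, `COc1cc(-c2cc(/C=C/C(=O)c3ccc(F)c(F)c3)[nH]n2)cc(OC)c1OC`, differs from compound 3 in one place: 3,4-difluorophenyl in place of 4-methoxyphenyl on a carbonyl carbon. The two large steps involving compound 2 bear on this change, since compound 4 also carries two halogens in the same arrangement. An upward step in this assay is therefore expected, though perhaps not the full size seen with the chlorines; the expected step is a number 24 percentage points higher from compound 3 to compound 4 (beyond the scatter). For compound 4 the estimated value is -15%, with a range from -35% to 5%.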

Compound 4, a percentage reported as activity, at one concentration (the size of the read-out at that concentration, not a potency): 1%
Compound 4: the middle estimate sits 16 percentage points below what was measured; low and high end bracket the measured number.
By their numbers in this assay, from the lowest: compounds 1 and 3 (each within the scatter of the next); then compounds 2 and 4 (each within the scatter of the next).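

On the carbonyl carbon, 3,4-difluorophenyl in place of 3,4-dichlorophenyl gives a number 6 percentage points higher from compound 2 to compound 4 (within the scatter) in this assay and so leaves the two halogen pairs indistinguishable here, which means the weaker effect seen earlier does not depend on chlorine alone. Putting 3,4-difluorophenyl in place of 4-methoxyphenyl gives a number 40 percentage points higher from compound 3 to compound 4 (beyond the scatter) and putting it in place of 4-aminophenyl gives a number 41 percentage points higher from compound 1 to compound 4 (beyond the scatter) as well, so among these four compounds both rings with two halogens sit at the weaker end and none goes against this. Nothing measured here explains why these rings differ from the other two.

From the compounds shown here alone, it remains open what a plain phenyl ring or a ring with a single fluorine would give. A ring carrying trifluoromethyl, a nitrile or a carboxylic acid is equally uncharted at this position.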